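The source may hold more compounds than are shown below. What is called first, only, known or untested is meant among the compounds shown, and "the series" means these compounds.

Compound 1 `CCC1(Cc2ccccc2)OS(=O)(=O)C=C1OCCCCc1ccccc1` gives 99000 nM in an ADME assay on HEL cells (Homo sapiens) for cytotoxicity, with a stated time of 3 days; on this read-out higher numbers stand for lower toxicity in this test and lower numbers for higher toxicity in this test.
Compound 2 `CCC1(Cc2ccccc2)OS(=O)(=O)C=C1OCc1ccc(Cl)cc1` reaches only the limit > 200000 nM in this assay.
Compound 3 `C=CCOC1=CS(=O)(=O)OC1(CC)Cc1ccccc1` reaches only the limit > 200000 nM in this assay.

Compound 1 holds the only number shown in this assay; the other two values are limits, as the limit of > 200000 nM in this assay, at which 2 of the 3 values shown sit, records. The two measured steps read an at least 2.0-fold higher number from compound 1 to compound 2 (0.30 log units; that floor lies within the scatter) and an at least 2.0-fold higher number from compound 1 to compound 3 (0.30 log units; that floor lies within the scatter), while a step that the two limits leave unreadable from compound 2 to compound 3 cannot be read. Compound 4 `CCC1(Cc2ccccc2)OS(=O)(=O)C=C1OCCc1ccccc1` differs from compound 1 by phenyl in place of phenethyl on a saturated chain carbon, two bonds along the chain from an oxygen on an unsaturated carbon. Both measured replacements of 3-phenylpropyl on that carbon ended at the limit, with floors that sit within the scatter, so for compound 4 a modest rise or none beyond the scatter is expected, a 1.5-fold higher number from compound 1 to compound 4 (0.18 log units; within the scatter). Compound 4 is therefore estimated at 150000 nM, between 70000 nM and 320000 nM.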

Compound 4, half-maximal cytotoxic concentration: 48000 nM
For compound 4 the middle estimate is 3.1-fold (0.49 log units) above the measured one, and the stated range ends above it.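

In this assay, within the data shown here, the shorter chain gives the first step at this position that reads beyond the scatter, and it runs downward, against the rise expected: a 2.1-fold lower number from compound 1 to compound 4 (0.31 log units; beyond the scatter). Compound 4 also falls away from the two compounds at the limit, with an at least 4.1-fold lower number from compound 3 to compound 4 (0.61 log units; beyond the scatter) and an at least 4.1-fold lower number from compound 2 to compound 4 (0.61 log units; beyond the scatter) as floors only, since those upper values are limits: the limit of > 200000 nM in this assay, at which 2 of the 4 values shown sit. Shortening the chain therefore does not by itself raise the number here.

The step between compound 2 and compound 3 cannot be read. As far as these compounds go, whether a longer chain, or an amine or a carboxylic acid at the chain end, would move the number stays open.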